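Lengthening the Chain Beyond the Ketone

This account rests on a few compounds, and the source may have more. Where it says the series, first, only, none or still open, it means among the compounds named here.

Of the compounds shown here, two have been measured in an assay on isolated protein for inhibition of histone deacetylase HD2 (Zea mays); a higher number here means a weaker inhibitor, a lower number a stronger inhibitor. Compound 1 `C/C(=C\c1cc(C(=O)c2ccccc2)cn1C)C(=O)NO` gives 2690 nM in this assay, and compound 2 `Cn1cc(C(=O)CCc2ccccc2)cc1/C=C/C(=O)NO` gives 42.7 nM. Of the two numbers, compound 2 stands lowest; compound 1 lies well above it, and that gap is beyond the scatter of repeated measurements.

Compound 3 `Cn1cc(C(=O)CCCCc2ccccc2)cc1/C=C/C(=O)NO` has not yet been measured. It differs from compound 2 in one place: phenethyl in place of phenyl on a saturated chain carbon, two bonds along the chain from a carbonyl carbon. The hydroxamic acid, the shared core and the carbonyl are all kept; only the saturated chain between the carbonyl carbon and the aromatic ring grows longer.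

Going by the values given here, no pair of measured compounds shows what such a lengthening does in this assay, so nothing among the measured compounds gives the direction of this step. In the absence of such a comparison, the step from compound 2 to compound 3 is expected to be a 1.4-fold higher number from compound 2 to compound 3 (0.15 log units; within the scatter), small and without a direction that can be told from the scatter. On that basis, compound 3 is estimated at 60 nM in this assay, with a likely range from 20 nM to 180 nM.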

Compound 3, half-maximal inhibitory concentration: 110 nM
For compound 3 the middle estimate is 1.8-fold (0.26 log units) below the measured one; low and high end bracket the measured number.
By their numbers in this assay, from the lowest: compound 2; then compound 3; then compound 1.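

Replacing phenyl with phenethyl on a saturated chain carbon, two bonds along the chain from a carbonyl carbon, gives a 2.6-fold higher number from compound 2 to compound 3 (0.41 log units; beyond the scatter) in this assay, so this position is not indifferent to the length of the chain. The step is modest. Going by these compounds alone, the hydroxamic acid, the shared core and the carbonyl are all kept, and this single change is the first one that can be read on its own. Nothing in hand says why the longer chain gives the higher number.

With only two chain lengths compared, the compounds shown cannot say whether a still longer chain would push the number further up in the same direction, or whether a chain of intermediate length would fall on the same trend. They also leave open how this position would respond if the aromatic ring at the end of the chain carried a methoxy group or a chlorine, or if an amine or a carboxylic acid stood in its place.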